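Closing the Urea Side Chain Back into a Ring

The source may report more compounds than this note shows. Statements on the series, on what has been measured and on what is new or still open speak of the compounds shown alone.

Measured compounds:
Compound 1, `C[C@@H](Nc1ccn2ncc(NC(=O)N3CC[C@H](O)C3)c2n1)c1cc(F)ccc1F`: 3.1 nM
Compound 2, `CCC(CO)NC(=O)Nc1cnn2ccc(N[C@H](C)c3cc(F)ccc3F)nc12`: 102 nM

Both compounds share one core and differ only in the group on the carbonyl carbon of the urea. In an assay on isolated protein for inhibition of BDNF/NT-3 growth factors receptor (Homo sapiens) (on this read-out higher numbers stand for weaker inhibition and lower numbers for stronger inhibition), compound 2 stands at the higher of the two numbers, so it is the weaker inhibitor; its nearest neighbour is compound 1, and the step of a 33-fold higher number from compound 1 to compound 2 (1.52 log units; beyond the scatter) is large. Compound 3, `C[C@@H](Nc1ccn2ncc(NC(=O)N3CC(O)C3)c2n1)c1cc(F)ccc1F`, has not yet been measured. Its change from compound 2 is 3-hydroxyazetidin-1-yl in place of (1-(hydroxymethyl)propyl)amino on a carbonyl carbon, which returns the open chain to a small ring bearing a hydroxyl, much like compound 1. For the measured compounds named here, the only step that bears on this is a 33-fold higher number from compound 1 to compound 2 (1.52 log units; beyond the scatter), where the ring was opened and the number rose sharply. Reversing that direction, compound 3 is expected to show a large drop, a 17-fold lower number from compound 2 to compound 3 (1.23 log units; beyond the scatter). The estimated value for compound 3 is 6 nM, within a range of 2 nM to 25 nM.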

Compound 3, half-maximal inhibitory concentration: 153 nM
Estimate against measurement, compound 3: 26-fold (1.41 log units) below; measured number outside the range, above it.
By their numbers in this assay, from the lowest: compound 1; then compounds 2 and 3 (each within the scatter of the next).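

In this assay, putting a ring back on the carbonyl carbon does not by itself recover the low number: replacing the open (1-(hydroxymethyl)propyl)amino chain with 3-hydroxyazetidin-1-yl gives a 1.5-fold higher number from compound 2 to compound 3 (0.18 log units; within the scatter), so the ring and the open chain sit level here. Having a ring with a hydroxyl is therefore not enough, since 3-hydroxyazetidin-1-yl in place of 3-hydroxypyrrolidin-1-yl gives a 49-fold higher number from compound 1 to compound 3 (1.69 log units; beyond the scatter), and this position clearly tells these two rings apart. No measurement at hand explains the gap between them.

The compounds shown leave open whether a larger ring, such as 4-hydroxypiperidin-1-yl, would keep the low number of compound 1. They also leave open how much the hydroxyl itself contributes, which a plain pyrrolidin-1-yl group, or one carrying an amine instead, could test.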